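The compounds below may be only part of what the source reports. "The series", "measured", "known", "first", "only" and "open" are said of these compounds alone.

Three compounds sharing one core have numbers or limits in a functional assay on MDA-MB-231 cells (Homo sapiens) for antiproliferative activity, read by MTT assay, with a stated time of 72 h (a higher number here means a weaker inhibitor, a lower number a stronger inhibitor), so far. Compound 1 `CC1=CCC2C(CC[C@@]2(C)O)C(C)(C)C1CC[C@@H]1[C@@]2(C)CC[C@@H](O)C(C)(C)O[C@@H]2CC[C@]1(C)O` is reported as > 50000 nM in this assay, which is a limit of the assay and not a number. Compound 2 `CC(=O)O[C@H]1CC[C@]2(C)[C@H](CC[C@@](C)(O)[C@H]2CC[C@@H]2C(C)=CC[C@H]3[C@H](CC[C@]3(C)OC(C)=O)C2(C)C)OC1(C)C` gives 26200 nM there and compound 3 `CC(=O)O[C@H]1CC[C@]2(C)[C@H](CC[C@@](C)(O)[C@H]2CC[C@@H]2C(C)=CC[C@@H]3C(C)=CC[C@@H]3C2(C)C)OC1(C)C` gives 39200 nM, and these two numbers lie within the scatter of each other. Compound 3 therefore stands level with compound 2, and neither can be ranked against the other.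

Compound 4 `CC1=CC[C@H]2[C@@H]1CC=C(C)[C@@H](CC[C@H]1[C@]3(C)CC[C@H](OC(=O)c4ccncc4)C(C)(C)O[C@H]3CC[C@@]1(C)O)C2(C)C` differs from compound 3 in one place: pyridin-4-yl in place of methyl on a carbonyl carbon, with pyridin-4-yl in place of methyl on a carbonyl carbon, so that acetoxy becomes ((pyridin-4-yl)carbonyl)oxy. Among the measured compounds shown here, no measured pair differs in a single place, so no measured step shows what such an exchange does in this assay. With compound 3 at 39200 nM as the starting point, a modest move towards a stronger inhibitor is expected, and not a large one. The expected size of the step is a 2.0-fold lower number from compound 3 to compound 4 (0.29 log units; within the scatter), which may not clear the scatter by much. For compound 4 the estimated value is 20000 nM, with an expected range of 6000 nM to 50000 nM.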

Compound 4, half-maximal inhibitory concentration: 19100 nM
Beside the measured number, compound 4's estimate is 1.0-fold (0.02 log units) above it, within the range that was stated.
By their numbers in this assay, from the lowest: compounds 4, 2 and 3 (each within the scatter of the next, the first and the last beyond it). At a limit, above all of these: compound 1.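

The step of a 2.1-fold lower number from compound 3 to compound 4 (0.31 log units; beyond the scatter) in this assay is the first exchange at a single place that can be read among these compounds, and it lies beyond the scatter, though its size is modest. It shows that this position, on a carbonyl carbon whose other neighbour is the oxygen of the ester, can carry pyridin-4-yl in place of methyl without any loss in this assay, and that acetoxy to ((pyridin-4-yl)carbonyl)oxy gives a lower number. The exchange alone does not carry the series far, however, since compound 4 still gives 19100 nM in this assay.

From the compounds shown here alone, it remains open whether a different group on the same carbonyl carbon, such as a phenyl ring, a pyridin-3-yl ring, an aminomethyl group or a longer alkyl chain, would move the number further than pyridin-4-yl does, and whether the same exchange would give a step of similar size on another part of the shared core. Compound 1 is reported only at a limit of the assay and not as a number, and so offers no step to read: the limit of > 50000 nM in this assay, at which 1 of the 4 values shown sits.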